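Nitro in place of methoxy: an estimate for compound 3

The source may report more compounds than this note shows. Statements on the series, on what has been measured and on what is new or still open speak of the compounds shown alone.

Measured in an ADME assay on MRC5 cells (Homo sapiens) for cytotoxicity, read by MTT assay, with a stated time of 6 days; on this read-out higher numbers stand for weaker inhibition and lower numbers for stronger inhibition:
Compound 1 `CC(=O)O[C@@H]1C=CC(=O)O[C@@H]1[C@@H](COC(=O)c1ccc([N+](=O)[O-])cc1)OC(C)=O`: > 100000 nM (a limit of the assay)
Compound 2 `COc1ccc(/C=C/C(=O)OC[C@@H](OC(C)=O)[C@H]2OC(=O)C=C[C@H]2OC(C)=O)cc1`: 78000 nM

Among the measured compounds shown here, compound 2 holds the only true number so far, 78000 nM. Compound 1 is known only as a limit, > 100000 nM. Compound 3 `CC(=O)O[C@@H]1C=CC(=O)O[C@@H]1[C@@H](COC(=O)/C=C/c1ccc([N+](=O)[O-])cc1)OC(C)=O` differs from compound 2 in one place, with nitro in place of methoxy on an aromatic carbon, para to a large group: nitro in place of methoxy on an aromatic carbon. For the measured compounds named here, one measured step bears on this, an at least 1.2-fold lower number from compound 1 to compound 2 (0.10 log units; that floor lies within the scatter). That step puts 2-(4-methoxyphenyl)ethenyl in place of 4-nitrophenyl on a carbonyl carbon, so it changes more than the group at issue here. Since it rests on a limit and its floor stays within the scatter, no step beyond the scatter is expected in this assay. The expected change is a 1.2-fold higher number from compound 2 to compound 3 (0.06 log units; within the scatter). For compound 3 the estimated value is 90000 nM, with an expected range of 45000 nM to 170000 nM.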

Compound 3, half-maximal inhibitory concentration: > 100000 nM
Compound 3 gave a limit, no number; the forecaster's own chance of this, stated with the estimate: 45%; middle value at least 1.1-fold (0.04 log units) from the limit.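

Nitro in place of methoxy on an aromatic carbon, para to a large group, gives an at least 1.2-fold higher number from compound 2 to compound 3 (0.10 log units; that floor lies within the scatter) in this assay. Among the compounds shown here, this is the first step that isolates that one change, since the earlier step also replaced the group joining the aromatic ring to the carbonyl carbon, yet its floor still lies within the scatter and its true size cannot be read. The value of compound 3 is a limit and not a number, and the read-out for this change stops there: the limit of > 100000 nM in this assay, at which 2 of the 3 values shown sit.

The compounds shown leave open how far compound 3 really lies from compound 2. They also leave open how an amine or a carboxylic acid on the same aromatic carbon would read in this assay.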